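Amide side-chain variation: hydroxymethyl to carboxy

The source may hold more compounds than are shown below. What is called first, only, known or untested is meant among the compounds shown, and "the series" means these compounds.

Working notes on the series. Three analogues share one core and differ only in the group on the amide-type nitrogen. Compound 1 `CCn1c(C(=O)NCC(=O)OC)ccc1C(CC)(CC)c1ccc(OCS(=O)(=O)c2ccccc2)c(C)c1` carries (methoxycarbonyl)methyl; in a functional assay on MCF7 cells (Homo sapiens) for antiproliferative activity, read by MTT assay, with a stated time of 24 h (a higher number here means a weaker inhibitor, a lower number a stronger inhibitor), compound 1 gives only a limit, > 50000 nM. Compound 2 `CCn1c(C(=O)NC2(CO)CC2)ccc1C(CC)(CC)c1ccc(OCS(=O)(=O)c2ccccc2)c(C)c1` carries 1-(hydroxymethyl)cyclopropyl, and in this assay compound 2 gives 28800 nM. Compound 3 `CCn1c(C(=O)N[C@@H](CO)C(C)C)ccc1C(CC)(CC)c1ccc(OCS(=O)(=O)c2ccccc2)c(C)c1` carries 1-(hydroxymethyl)-2-methylpropyl, and in this assay compound 3 gives 18800 nM, the lowest of the two numbers shown, though its gap to compound 2 stays within the scatter. The steps read an at least 1.7-fold lower number from compound 1 to compound 2 (0.23 log units; that floor lies within the scatter), an at least 2.6-fold lower number from compound 1 to compound 3 (0.42 log units; beyond the scatter) and a 1.5-fold lower number from compound 2 to compound 3 (0.19 log units; within the scatter); the first two rest on (the limit of > 50000 nM in this assay, at which 1 of the 3 values shown sits).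

Compound 4 `CCn1c(C(=O)N[C@@H](C(=O)O)C(C)C)ccc1C(CC)(CC)c1ccc(OCS(=O)(=O)c2ccccc2)c(C)c1` is not yet measured. Its change from compound 3 is carboxy in place of hydroxymethyl on a saturated chain carbon bound to an amide-type nitrogen and a saturated chain carbon. For the measured compounds named here, no measured step exchanges hydroxymethyl for carboxy, so none bears on it directly; the only related comparison is that the ester-bearing compound 1 sits at a limit while both hydroxymethyl compounds give numbers. Compound 4 is expected to give a somewhat higher number in this assay, the step of a 1.7-fold higher number from compound 3 to compound 4 (0.23 log units; within the scatter) being estimated as modest, with a limit readout a real possibility. The estimate for compound 4 is 32000 nM, ranging from 12000 nM to 85000 nM.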

Compound 4, half-maximal inhibitory concentration: 44700 nM
Estimate against measurement, compound 4: 1.4-fold (0.15 log units) below, within the range that was stated.
By their numbers in this assay, from the lowest: compounds 3, 2 and 4 (each within the scatter of the next, the first and the last beyond it). At a limit, above all of these: compound 1.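

For the compounds shown here, on the saturated chain carbon bound to an amide-type nitrogen and a saturated chain carbon, the direct exchange of hydroxymethyl for carboxy gives a 2.4-fold higher number from compound 3 to compound 4 (0.38 log units; beyond the scatter) in this assay, the first measured reading of this change and one that lies beyond the scatter. Across the two different side chains the picture is less sharp, with a 1.6-fold higher number from compound 2 to compound 4 (0.19 log units; within the scatter), so the 1-carboxy-2-methylpropyl compound separates from the 1-(hydroxymethyl)-2-methylpropyl compound but not from the 1-(hydroxymethyl)cyclopropyl compound. The remaining step, an at least 1.1-fold lower number from compound 1 to compound 4 (0.04 log units; that floor lies within the scatter), is only a floor and does not place the carboxy compound relative to the (methoxycarbonyl)methyl compound, whose reading is a limit: the limit of > 50000 nM in this assay, at which 1 of the 4 values shown sits.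

From the compounds shown here alone, whether the cost of this change holds on other side chains stays open, as the series shows the exchange on the 1-(hydroxymethyl)-2-methylpropyl chain alone. A methyl ester, a primary carboxamide or an amine in place of the carboxy on this same carbon would show whether the step follows the carboxy group itself or any replacement of hydroxymethyl at this position.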